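Geometry and aryl swap in a chalcone-type ester series

This account rests on a few compounds, and the source may have more. Where it says the series, first, only, none or still open, it means among the compounds named here.

Measured compounds:
compound 1, `O=C(OC/C(=C\c1ccc(Cl)cc1Cl)C(=O)c1ccccc1)c1ccccc1`, 3100 nM
compound 2, `O=C(OC/C(=C\c1ccccc1[N+](=O)[O-])C(=O)c1ccccc1)c1ccccc1`, 3900 nM
compound 3, `O=C(OC/C(=C/c1ccc(Cl)cc1Cl)C(=O)c1ccccc1)c1ccccc1`, 26000 nM

In a functional assay on HBL-100 cells (Homo sapiens) for inhibition, read by sulforhodamine B assay, with a stated time of 48 h (on this read-out higher numbers stand for weaker inhibition of growth and lower numbers for stronger inhibition of growth), compound 1 gives 3100 nM and compound 2 gives 3900 nM; the two sit within the scatter of each other, a 1.3-fold higher number from compound 1 to compound 2 (0.10 log units; within the scatter). The change between them is 2-nitrophenyl in place of 2,4-dichlorophenyl on a double-bonded chain carbon bound to a double-bonded chain carbon. Compound 3 stands apart: in this assay compound 3 gives 26000 nM, and an 8.4-fold higher number from compound 1 to compound 3 (0.92 log units; beyond the scatter). The cores of compound 1 and compound 3 differ only in this way: the two compounds have the same atoms and bonds and differ only in configuration as drawn: 1 of 1 stereo elements differ; a double bond is drawn E in compound 1 and Z in compound 3, which is the whole of what separates them (the fact that compounds 1 and 3 differ only in the configuration as drawn).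

Compound 4, `O=C(OC/C(=C/c1ccccc1[N+](=O)[O-])C(=O)c1ccccc1)c1ccccc1`, is not yet measured. It stands to compound 3 as compound 2 stands to compound 1: 2-nitrophenyl in place of 2,4-dichlorophenyl on a double-bonded chain carbon bound to a double-bonded chain carbon, the same kind of change, made on the same place. Among the measured compounds shown here, since that change gave only a 1.3-fold higher number from compound 1 to compound 2 (0.10 log units; within the scatter), a step of similar size is expected here, a 1.2-fold higher number from compound 3 to compound 4 (0.09 log units; within the scatter), resting on the one earlier step. Compound 4 is therefore estimated at 32000 nM in this assay, between 12000 nM and 85000 nM.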

Compound 4, concentration for 50% growth inhibition: > 100000 nM
Compound 4 ended at the assay's limit (the forecaster's own chance of this, stated with the estimate: 15%); at least 3.1-fold (0.49 log units) between middle value and limit.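

The change did not carry over in size from one core to the other: on the core of compound 3 it gives an at least 3.8-fold higher number from compound 3 to compound 4 (0.58 log units; beyond the scatter) in this assay, whereas on the core of compound 1 it stayed within the scatter: the same change on two cores in this assay, a 1.3-fold higher number (0.10 log units; within the scatter) from compound 1 to compound 2 and an at least 3.8-fold higher number (0.58 log units; beyond the scatter) from compound 3 to compound 4, at least 3.0-fold (0.48 log units) apart, beyond the scatter of two such steps Both cores do share one direction, with the double bond drawn Z rather than E giving an 8.4-fold higher number from compound 1 to compound 3 (0.92 log units; beyond the scatter) and an at least 25-fold higher number from compound 2 to compound 4 (1.40 log units; beyond the scatter). Compound 4 gives > 100000 nM, which is a limit of the assay and not a number, so this pair of cores does not show the true size of the gap between the two steps, nor whether it would recur with any other group.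

The compounds shown leave open whether a plain phenyl or a 4-methoxyphenyl on a double-bonded chain carbon would follow the 2-nitrophenyl or the 2,4-dichlorophenyl pair on each core. They also leave open how either geometry would fare with an amide in place of the benzoate ester.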